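Cytotoxicity notes on the series before compound 4

This account rests on a few compounds, and the source may have more. Where it says the series, first, only, none or still open, it means among the compounds named here.

Three members of the series have been run in an ADME assay on MRC5 cells (Homo sapiens) for cytotoxicity; on this read-out higher numbers stand for lower toxicity in this test and lower numbers for higher toxicity in this test. Compound 1 `Cc1cn([C@@H]2C[C@H](O)[C@@H](CNC(=S)Nc3ccc(Cl)c(C(F)(F)F)c3)O2)c(=O)[nH]c1=O` carries a thiourea linked to an aromatic ring bearing chloro and trifluoromethyl groups; in this assay compound 1 gives > 50000 nM, which is a limit of the assay rather than a number. Compound 2 `Cc1cn([C@@H]2C[C@H](O)[C@@H](CNC(=S)Nc3ccc(OCc4ccccc4)cc3)O2)c(=O)[nH]c1=O` keeps the thiourea and carries a benzyloxy group on its aromatic ring; in this assay compound 2 gives > 50000 nM, again a limit. Compound 3 `Cc1cn([C@@H]2C[C@H](O)[C@@H](CNC(=O)Nc3ccc(OC4CCOCC4)cc3)O2)c(=O)[nH]c1=O` has a urea instead of the thiourea and an oxan-4-yl ether on the aromatic ring; in this assay compound 3 gives > 50000 nM, also a limit. Compound 3 therefore stands together with the other two at the limit of > 50000 nM in this assay, at which 3 of the 3 values shown sit, and no ordering among the three can be drawn.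

Compound 4 `COc1ccc(COc2ccc(NC(=O)NC[C@H]3O[C@H](n4cc(C)c(=O)[nH]c4=O)C[C@@H]3O)cc2)cc1` differs from compound 3 by 4-methoxybenzyl in place of oxan-4-yl on an oxygen on an aromatic ring. Going by the values given here, no step between measured compounds exists to calibrate this change. Because compound 3 gives > 50000 nM in this assay, a limit, the step from compound 3 to compound 4 is expected to be a number no higher from compound 3 to compound 4 (the limit leaves the size open), that is none beyond the scatter. The estimate for compound 4 in this assay is 50000 nM, with a range from 25000 nM to 100000 nM, most likely reported again as a limit.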

Compound 4, half-maximal cytotoxic concentration: > 50000 nM
Compound 4 ended at the assay's limit; the forecaster's own chance of this, stated with the estimate: 80%; the middle value lies on the limit itself.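

In this assay compound 4 gives > 50000 nM, a limit and not a number. With compound 3 also at a limit, no step can be read between compound 3 and compound 4, and all four compounds stay together: the limit of > 50000 nM in this assay, at which 4 of the 4 values shown sit.

The compounds shown leave open which change to the shared core, if any, would give a readable number in this assay.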